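The compounds below may be only part of what the source reports. "The series", "measured", "known", "first", "only" and "open" are said of these compounds alone.

Working notes on the series. Compound 2 `CC1CC/C(=N\Nc2ccc(C(F)(F)F)cc2)c2ncc(C(=O)O)c(=O)n21` is the reference for the next step. In a functional assay on the whole organism for inhibition, with Rattus norvegicus as the target (on this read-out lower numbers stand for an effect already at smaller amounts and higher numbers for an effect only at larger amounts of compound), compound 2 gives only a limit, > 1000 umol/kg. Compound 1 `CC1CC/C(=N\Nc2ccc(F)cc2)c2ncc(C(=O)O)c(=O)n21` likewise gives a limit in this assay, > 1000 umol/kg. Among the measured compounds shown here, the single measured step, a step that the two limits leave unreadable from compound 1 to compound 2, is unreadable, since (the limit of > 1000 umol/kg in this assay, at which 2 of the 2 values shown sit). Compound 3 `CC(C)c1ccc(N/N=C2\CCC(C)n3c2ncc(C(=O)O)c3=O)cc1` carries isopropyl in place of trifluoromethyl on an aromatic carbon. For the measured compounds named here, no measured step bears on this change, and neither value shown is a number, so no direction beyond the scatter can be expected. Compound 3 is estimated at 1500 umol/kg, with a range from 500 umol/kg to 5000 umol/kg, which would be the expected step that the limit leaves unreadable from compound 2 to compound 3.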

Compound 3, dose for 50% inhibition: > 100 umol/kg
Compound 3 gave a limit, no number; the forecaster's own chance of this, stated with the estimate: 75%; the middle value does not contradict the limit.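

In this assay, among the compounds shown here, compound 1, compound 2 and compound 3 give only limits, so no step among them can be read. The compounds shown leave open whether fluoro, trifluoromethyl or isopropyl on the aromatic carbon makes any difference to the effect.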